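Cytotoxicity of trimethoxyphenyl pyrazole chalcones at low concentration

A few compounds are considered here, and "the series" means these few. Any claim that something is new, unique, unknown or untested is made for them only; others in the source may bear on it.

Measured compounds:
compound 1, `COc1cc(-c2cc(/C=C/C(=O)c3ccc(Cl)c(Cl)c3)[nH]n2)cc(OC)c1OC`, 99%
compound 2, `COc1ccc(C(=O)/C=C/c2cc(-c3cc(OC)c(OC)c(OC)c3)n[nH]2)cc1`, 100%

The two compounds share a core and differ only in the aryl group on the carbonyl carbon. In a functional assay on SK-OV-3 cells (Homo sapiens) for cytotoxicity, read by sulforhodamine B assay, with a stated time of 48 h, tested at 0.01 uM (a lower number here means a stronger effect, a higher number a weaker effect of the compound at the concentration tested), compound 1 gives 99%, and compound 2 gives 100%. Compound 2 therefore stands with compound 1: the step of a number 1 percentage points higher from compound 1 to compound 2 (within the scatter) shows that the two numbers cannot be told apart, and neither compound reaches a meaningful effect at the concentration tested.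

Compound 3, `COc1cc(-c2cc(/C=C/C(=O)c3ccc(F)c(F)c3)[nH]n2)cc(OC)c1OC`, has not been measured. It differs from compound 2 as follows: 3,4-difluorophenyl in place of 4-methoxyphenyl on a carbonyl carbon. Among the compounds with values here, the one measured step that bears on this change, a number 1 percentage points higher from compound 1 to compound 2 (within the scatter), also swapped the aryl group on the carbonyl carbon, and it stayed within the scatter. On that basis no step beyond the scatter is expected from compound 2 to compound 3 in this assay; the expected step is a number 1 percentage points lower from compound 2 to compound 3 (within the scatter). Compound 3 is accordingly estimated to give 99%, with a range from 89% to 107%.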

Compound 3, a percentage reported as activity, at one concentration (the size of the read-out at that concentration, not a potency): 98%
Compound 3: the middle estimate sits 1 percentage points above what was measured; low and high end bracket the measured number.
By their numbers in this assay, from the lowest: compounds 3, 1 and 2 (each within the scatter of the next).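

With compound 3, a third aryl group on the carbonyl carbon has been read in this assay: replacing 4-methoxyphenyl with 3,4-difluorophenyl gives a number 2 percentage points lower from compound 2 to compound 3 (within the scatter) and replacing 3,4-dichlorophenyl with it gives a number 1 percentage points lower from compound 1 to compound 3 (within the scatter) in the same assay. Within the data shown here, the earlier pair offered only one swap at this place, whereas the three compounds now give three comparisons, and none of them leaves the scatter, whether the ring carries chlorine, fluorine or a methoxy group. No measurement is available that would account for this flat result.

Going by these compounds, at this single low concentration, all three compounds sit so close together that the reading cannot show whether the aryl group on the carbonyl carbon matters at all, and whether these three groups would separate at higher concentrations remains open. The compounds shown also leave open how this place would respond to an aryl group carrying an amine or a carboxylic acid, or to a saturated alkyl chain in place of the aryl ring.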